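Trading 3-methylbenzyl for 4-chlorobenzyl in a cell assay

This account rests on a few compounds, and the source may have more. Where it says the series, first, only, none or still open, it means among the compounds named here.

Measured in a functional assay on HCT-116 cells (Homo sapiens) for inhibition, read by MTT assay, with a stated time of 72 h; on this read-out higher numbers stand for weaker inhibition and lower numbers for stronger inhibition:
Compound 1 `O=C1/C(=C\c2ccccc2)c2c(ncn2COCc2ccccc2)CCN1Cc1ccccc1` gives 20000 nM
Compound 2 `O=C1/C(=C\c2ccccc2)c2c(ncn2COCc2ccccc2)CCN1Cc1ccc(F)cc1` gives 11200 nM
Compound 3 `Cc1cccc(CN2CCc3ncn(COCc4ccccc4)c3/C(=C/c3ccccc3)C2=O)c1` gives 3800 nM

A lower number means stronger inhibition, so compound 3 stands best of the three, with clear gaps to both others. Compound 4 `O=C1/C(=C\c2ccccc2)c2c(ncn2COCc2ccccc2)CCN1Cc1ccc(Cl)cc1` carries 4-chlorophenyl in place of 3-methylphenyl on a saturated chain carbon bound to an amide-type nitrogen in a ring. This removes the methyl, and that methyl accounted for a 5.3-fold lower number from compound 1 to compound 3 (0.72 log units; beyond the scatter) when it replaced hydrogen. A halogen in the same named position did much less, as fluoro in place of hydrogen gave a 1.8-fold lower number from compound 1 to compound 2 (0.25 log units; within the scatter). The closest comparison is a 2.9-fold lower number from compound 2 to compound 3 (0.47 log units; beyond the scatter), which compound 4 should largely walk back. Among the measured compounds shown here, no chloro compound has been measured yet, so chloro may differ from fluoro. A modest rise in the number is therefore expected, and the estimate is a 2.1-fold higher number from compound 3 to compound 4 (0.32 log units; beyond the scatter). Compound 4 is estimated at 8000 nM, with an expected range from 3000 nM to 20000 nM.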

Compound 4, half-maximal inhibitory concentration: 10500 nM
Compound 4: middle estimate off by 1.3-fold (0.12 log units), on the low side; measured number inside the range.
By their numbers in this assay, from the lowest: compound 3; then compounds 4, 2 and 1 (each within the scatter of the next).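

In this assay, swapping the 3-methylbenzyl group of compound 3 for 4-chlorobenzyl costs activity (a 2.8-fold higher number from compound 3 to compound 4 (0.44 log units; beyond the scatter)), a step beyond the scatter. Chloro and fluoro cannot be told apart on this benzyl group (a 1.1-fold lower number from compound 2 to compound 4 (0.03 log units; within the scatter)), and chloro cannot be told apart from hydrogen either (a 1.9-fold lower number from compound 1 to compound 4 (0.28 log units; within the scatter)), so among these four compounds only compound 3 stands apart from the others. Nothing available explains why the 3-methylbenzyl compound behaves differently.

The compounds shown leave open whether the methyl group itself or its place on the ring matters, a question that 4-methylbenzyl and 3-chlorobenzyl would help to settle. Going by these compounds, how a benzyl group carrying an amine or a carboxylic acid would behave in this assay also remains open.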